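Series notes: ketone to anilide step in this assay

A few compounds are considered here, and "the series" means these few. Any claim that something is new, unique, unknown or untested is made for them only; others in the source may bear on it.

Measured in a functional assay on HeLa cells (Homo sapiens) for antiproliferative activity, read by MTT assay, with a stated time of 48 h; a lower number here means a stronger inhibitor, a higher number a weaker inhibitor:
Compound 1 `COc1cc(-c2nnc(SCC(=O)c3ccccc3)n2N)cc(OC)c1OC` gives > 100000 nM, a limit of the assay.
Compound 2 `COc1cc(-c2nnc(SCC(=O)c3ccc(F)c(F)c3)n2N)cc(OC)c1OC` gives > 100000 nM, also a limit.
Compound 3 `COc1cc(-c2nnc(SCC(=O)c3ccccc3F)n2N)cc(OC)c1OC` gives 80100 nM.

Among the measured compounds shown here, compound 3 thus holds the only read number in the set; the other two values are limits, as the limit of > 100000 nM in this assay, at which 2 of the 3 values shown sit, records. The steps read an at least 1.2-fold lower number from compound 1 to compound 3 (0.09 log units; that floor lies within the scatter) and an at least 1.2-fold lower number from compound 2 to compound 3 (0.09 log units; that floor lies within the scatter), both floors within the scatter, and a step that the two limits leave unreadable from compound 1 to compound 2.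

Compound 4 `COc1cc(-c2nnc(SCC(=O)Nc3ccccc3)n2N)cc(OC)c1OC` differs from compound 3 by anilino in place of 2-fluorophenyl on a carbonyl carbon. For the measured compounds named here, no measured step exchanges a ketone for an amide; the steps at the aryl end, an at least 1.2-fold lower number from compound 1 to compound 3 (0.09 log units; that floor lies within the scatter) and an at least 1.2-fold lower number from compound 2 to compound 3 (0.09 log units; that floor lies within the scatter), are small. The expected step of a 1.2-fold higher number from compound 3 to compound 4 (0.10 log units; within the scatter) is therefore none beyond the scatter, with a fair chance of a limit. Compound 4 is estimated at 100000 nM, range 40000 nM to 250000 nM.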

Compound 4, half-maximal inhibitory concentration: 8280 nM
Compound 4: middle estimate off by 12-fold (1.08 log units), on the high side; measured number below the stated range.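

In this assay, the ketone to anilide change is the only one at this carbonyl carbon with a fully read step beyond the scatter: a 9.7-fold lower number from compound 3 to compound 4 (0.99 log units; beyond the scatter). The steps of an at least 12-fold lower number from compound 2 to compound 4 (1.08 log units; beyond the scatter) and an at least 12-fold lower number from compound 1 to compound 4 (1.08 log units; beyond the scatter) are floors rather than sizes: the limit of > 100000 nM in this assay, at which 2 of the 4 values shown sit. Thus, the group on the carbonyl matters more through its linking atom than the fluoro changes on the ketone aryl ring could show.

As far as these compounds go, whether the amide hydrogen carries the step remains open; a methyl on the amide nitrogen would test that. From the compounds shown here alone, the effect of fluoro on the anilino ring also remains open.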